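The compounds below may be only part of what the source reports. "The series", "measured", "known", "first", "only" and "open" are said of these compounds alone.

In an ADME assay (Homo sapiens) for cytotoxicity (on this read-out higher numbers stand for lower toxicity in this test and lower numbers for higher toxicity in this test), three compounds of this series have been measured. Compound 1 `CC(=O)N1CCC(C(=O)N(CCCN2CCC(CNC(=O)c3cnccn3)CC2)c2ccc(C)c(Cl)c2)CC1` gives only a limit in this assay, > 52400 nM. That limit is the limit of > 52400 nM in this assay, at which 1 of the 3 values shown sits. Compound 3 `CCN(Cc1ccccc1)C(=O)C1CCN(CCCN(C(=O)C2CCN(C(C)=O)CC2)c2ccc(C)c(Cl)c2)CC1` gives 83.9 nM. Between these two stands the single measured step between compounds that differ in one place, an at least 620-fold lower number from compound 1 to compound 3 (2.79 log units; beyond the scatter). Compound 2 `CC(=O)N1CCC(C(=O)N(CCCN2CCN(Cc3ccc(C#N)cc3)CC2)c2ccc(C)c(Cl)c2)CC1` also gives only a limit in this assay, > 100000 nM. This is the limit of > 100000 nM in this assay, at which 1 of the 3 values shown sits, where one of the three values sits, so compound 2 stands at the least toxic end of what has been seen.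

Compound 4 `CC(=O)N1CCC(C(=O)N(CCCN2CCN(Cc3ccc(Cl)nc3)CC2)c2ccc(C)c(Cl)c2)CC1` has not yet been measured. It differs from compound 2 by 6-chloropyridin-3-yl in place of 4-cyanophenyl on a saturated chain carbon bound to an amine nitrogen in a ring. Within the data shown here, the measured step from compound 1 to compound 3 changes a different part of the shared core and starts from a different compound, so it does not bear on this change, and no measured step touches the changed group. Compound 4 is therefore expected to stay close to compound 2, with a step of a number no higher from compound 2 to compound 4 (the limit leaves the size open) not beyond the scatter. Compound 4 is estimated at 100000 nM, in a range from 30000 nM to 100000 nM.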

Compound 4, half-maximal cytotoxic concentration: > 53100 nM
Compound 4: only a limit was reported (the forecaster's own chance of this, stated with the estimate: 65%); the middle value is on the limit's open side.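

Compound 2 and compound 4 each give only a limit in this assay, so the step between them cannot be read. The compounds shown leave open whether 6-chloropyridin-3-yl in place of 4-cyanophenyl changes the half-maximal cytotoxic concentration at all, and by how much.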